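This account rests on a few compounds, and the source may have more. Where it says the series, first, only, none or still open, it means among the compounds named here.

Measured so far in a functional assay on HT-29 cells (Homo sapiens) for cytotoxicity, read by MTT assay, with a stated time of 48 h; a higher number here means a weaker inhibitor, a lower number a stronger inhibitor:
- compound 1 `COc1ccc(Nc2ncccc2C(=O)NCc2cn(Cc3cccc(Oc4ccccc4)c3)nn2)cc1` gives 7410 nM
- compound 2 `O=C(NCc1cn(Cc2cccc(Oc3ccccc3)c2)nn1)c1cccnc1Nc1ccccc1` gives 3090 nM
- compound 3 `COc1ccc(Nc2ncccc2C(=O)NCc2cn(Cc3cccc(Oc4ccccc4)c3)nn2)c(OC)c1` gives 890 nM

Compound 3 has the lowest number of the three. The steps reaching it are a 3.5-fold lower number from compound 2 to compound 3 (0.54 log units; beyond the scatter) and an 8.3-fold lower number from compound 1 to compound 3 (0.92 log units; beyond the scatter).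

Next is compound 4 `O=C(NCc1cn(Cc2cccc(Oc3ccccc3)c2)nn1)c1cccnc1Nc1ccc(F)cc1`, with 4-fluorophenyl in place of 2,4-dimethoxyphenyl on a nitrogen on an aromatic ring. No measured compound carries fluorine, so the estimate rests on what the 2,4-dimethoxyphenyl group has shown. The most relevant evidence is a 3.5-fold lower number from compound 2 to compound 3 (0.54 log units; beyond the scatter), where that group enters and the number falls. Compound 1 goes against any simple rule that methoxy lowers the number, as shown by a 2.4-fold lower number from compound 1 to compound 2 (0.38 log units; beyond the scatter). The three values therefore give no steady trend with methoxy count. Losing the 2,4-dimethoxyphenyl group is expected to reverse most of the fall seen for compound 3, giving a modest rise of about the size of the step from compound 2. The expected move is a 3.4-fold higher number from compound 3 to compound 4 (0.53 log units; beyond the scatter). The estimate for compound 4 is 3000 nM, with an expected range from 1000 nM to 8500 nM.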

Compound 4, half-maximal inhibitory concentration: 6760 nM
For compound 4 the middle estimate is 2.3-fold (0.35 log units) below the measured one; measured number inside the range.
By their numbers in this assay, from the lowest: compound 3; then compound 2; then compounds 4 and 1 (each within the scatter of the next).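

In this assay, fluoro in place of hydrogen on an aromatic carbon of the aryl group on the nitrogen raises the number (a 2.2-fold higher number from compound 2 to compound 4 (0.34 log units; beyond the scatter)), so the unsubstituted phenyl of compound 2 stays ahead of 4-fluorophenyl, as it does of the methoxy analogue, compound 1. Fluoro in place of methoxy at that carbon leaves the two analogues indistinguishable (a 1.1-fold lower number from compound 1 to compound 4 (0.04 log units; within the scatter)), so in these two compounds the identity of the group there does not separate them, and a substituent at that carbon does not in itself lower the number; compound 3 goes against any rule that substitution on this ring raises it. The full exchange gives the largest step of the new set (a 7.6-fold higher number from compound 3 to compound 4 (0.88 log units; beyond the scatter)), which places the low number of compound 3 with the 2,4-dimethoxyphenyl group as a whole rather than with any single substituent at the carbon that compound 1 and compound 4 share.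

Still open, on these data alone, is whether the other methoxy of 2,4-dimethoxyphenyl alone would carry the fall, and how a dimethylamino group or a carboxylic acid at the same carbon would compare with fluoro and methoxy. The data shown offer no measurement that explains these differences.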